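The source may report more compounds than this note shows. Statements on the series, on what has been measured and on what is new or still open speak of the compounds shown alone.

Measured so far:

Compound 1, `Nc1sc2c(c1C(=O)O)CCN(Cc1ccccc1)C2`, gives 8000 nM in an in vitro assay on CHOk1 cells with adenosine receptor A1 (Homo sapiens) as the target; a lower number here means that less compound is needed, a higher number that more compound is needed for the effect.
Compound 2, `CC(C)(C)OC(=O)N1CCc2c(sc(N)c2C(=O)O)C1`, gives 12100 nM in this assay.
Compound 3, `CN1CCc2c(sc(N)c2C(=O)NCc2cccc(Cl)c2)C1`, gives 13200 nM in this assay.

All three compounds share one core, a five-membered aromatic ring with one sulfur fused to a saturated ring that carries a nitrogen, and an amino group on the aromatic ring. Compound 2 stands second highest of these three numbers, but its gap to compound 3 and its gap to compound 1 both lie within the usual scatter of repeated measurements, so the three compounds cannot be told apart on these numbers; each needs a large amount of compound for the effect.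

Compound 4, `CC(C)(C)OC(=O)N1CCc2c(sc(N)c2C#N)C1`, has not yet been measured. It differs from compound 2 in one place: cyano in place of carboxy on an aromatic carbon. The carboxy group leaves and a cyano group enters, so one hydrogen-bond donor is lost while one hydrogen-bond acceptor remains.

Within the data shown here, no step between measured compounds covers a change of this kind, so there is nothing here that says how the exchange acts in this assay. With all three measured numbers so close, the expectation for compound 4 is a number near compound 2, with no step beyond the scatter in either direction, a step of a 1.2-fold higher number from compound 2 to compound 4 (0.06 log units; within the scatter). Compound 4 is thus estimated at 14000 nM, with a range from 4000 nM to 50000 nM.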

Compound 4, half-maximal effective concentration: > 20000 nM
Compound 4: a limit, no number; the forecaster's own chance of this, stated with the estimate: 25%; middle value at least 1.4-fold (0.15 log units) from the limit.
By their numbers in this assay, from the lowest: compounds 1, 2 and 3 (each within the scatter of the next). At a limit, above all of these: compound 4.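

Compound 4 gives > 20000 nM in this assay, which is a limit of the assay and not a number. This is the first change shown on this aromatic carbon of the shared core, and cyano in place of carboxy comes out as an at least 1.6-fold higher number from compound 2 to compound 4 (0.21 log units; that floor lies within the scatter), so losing the hydrogen-bond donor of the carboxy group brings no lower number, while the true size of the step stays unknown. What can be read from this pair therefore ends at a floor, and that floor is set by the assay and not by a measured number for compound 4: the limit of > 20000 nM in this assay, at which 1 of the 4 values shown sits.

The compounds shown leave open how far compound 4 lies past this limit, and so whether the exchange of carboxy for cyano has an effect beyond the scatter at all. They also leave open what a methyl ester or a primary carboxamide would do on this same aromatic carbon with the rest of compound 2 unchanged, and whether any group there could bring the number down.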